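Chloro series: sulfonyl cyclopropane demethylation, rat microsome clearance

The source may hold more compounds than are shown below. What is called first, only, known or untested is meant among the compounds shown, and "the series" means these compounds.

Measured so far:
compound 1 `COc1ccc2c(OCC[C@@H]3NC(=O)N(C)CCCC/C=C\[C@@H]4C[C@@]4(C(=O)NS(=O)(=O)C4(C)CC4)NC3=O)cc(-c3nc(C(C)C)cs3)nc2c1`: 155 mL.min-1.g-1
compound 2 `COc1ccc2c(OCC[C@@H]3NC(=O)N(C)CCCC/C=C\[C@@H]4C[C@@]4(C(=O)NS(=O)(=O)C4(C)CC4)NC3=O)cc(-c3nc(C(C)C)cs3)nc2c1Cl`: 20.7 mL.min-1.g-1

In an ADME assay (liver) for metabolic stability, with Liver microsome (Rattus norvegicus) as the target, using microsomes, with a stated time of 2 h (on this read-out lower numbers stand for slow clearance and higher numbers for fast clearance), compound 2 gives the lowest of the two numbers; compound 1 sits a step above it, a 7.5-fold lower number from compound 1 to compound 2 (0.87 log units; beyond the scatter). Compound 3 `COc1ccc2c(OCC[C@@H]3NC(=O)N(C)CCCC/C=C\[C@@H]4C[C@@]4(C(=O)NS(=O)(=O)C4CC4)NC3=O)cc(-c3nc(C(C)C)cs3)nc2c1Cl` differs from compound 2 by hydrogen in place of methyl on a saturated ring carbon. For the measured compounds named here, no measured step touches this position, so the one step seen, on the aromatic ring, does not inform it. The expectation for compound 3 is a step within the scatter, a 1.2-fold higher number from compound 2 to compound 3 (0.08 log units; within the scatter), estimated at 25 mL.min-1.g-1 with a range from 11 mL.min-1.g-1 to 55 mL.min-1.g-1.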

Compound 3, intrinsic clearance in microsomes: 36.6 mL.min-1.g-1
Beside the measured number, compound 3's estimate is 1.5-fold (0.17 log units) below it, and the stated range covers the measured number.
By their numbers in this assay, from the lowest: compounds 2 and 3 (each within the scatter of the next); then compound 1.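

In this assay, the change from 1-methylcyclopropyl to cyclopropyl gives a 1.8-fold higher number from compound 2 to compound 3 (0.25 log units; within the scatter). On this chloro background, the methyl on the saturated ring carbon can therefore be removed with no shift that stands out from the scatter. No available measurement accounts for this result.

From the compounds shown here alone, whether the same change reads alike on the hydrogen analogue, compound 1, remains open. Also open, going by these compounds, is how an ethyl, a trifluoromethyl or an amine on this ring carbon would read.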